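Trading 3-ethynylphenyl for 3,4,5-trifluorophenyl on the anilino nitrogen

This account rests on a few compounds, and the source may have more. Where it says the series, first, only, none or still open, it means among the compounds named here.

Compound 1, `C#Cc1cccc(Nc2ncnc3cc(OC)c(OCCCCC(=O)Nc4ccc(S(N)(=O)=O)cc4)cc23)c1`, gives 7720 nM in a functional assay on A549 cells (Homo sapiens) for antiproliferative activity, read by MTT assay, with a stated time of 72 h; a lower number here means a stronger inhibitor, a higher number a weaker inhibitor.
Compound 2, `COc1cc2ncnc(Nc3ccc(Cl)cc3)c2cc1OCCCCC(=O)Nc1ccc(S(N)(=O)=O)cc1`, gives only > 40000 nM in this assay, which is a limit of the assay and not a number.

Among the compounds with values here, compound 1 therefore holds the only real number in this assay; compound 2 sits at the limit of > 40000 nM in this assay, at which 1 of the 2 values shown sits. Compound 3, `COc1cc2ncnc(Nc3cc(F)c(F)c(F)c3)c2cc1OCCCCC(=O)Nc1ccc(S(N)(=O)=O)cc1`, has not yet been measured. It differs from compound 1 by 3,4,5-trifluorophenyl in place of 3-ethynylphenyl on a nitrogen on an aromatic ring. Within the data shown here, one measured step bears on this position: an at least 5.1-fold higher number from compound 1 to compound 2 (0.71 log units; beyond the scatter), where another group replaced 3-ethynylphenyl on the same nitrogen and the number climbed beyond the scatter. Because the step from compound 1 to compound 2 was an at least 5.1-fold higher number from compound 1 to compound 2 (0.71 log units; beyond the scatter), a loss of similar size is expected for compound 3, namely a 3.2-fold higher number from compound 1 to compound 3 (0.51 log units; beyond the scatter). Compound 3 is thus estimated to give 25000 nM in this assay, with a range from 8000 nM to 60000 nM, and a real chance that only a limit is returned.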

Compound 3, half-maximal inhibitory concentration: > 40000 nM
Compound 3 gave a limit, no number (the forecaster's own chance of this, stated with the estimate: 35%); at least 1.6-fold (0.20 log units) between middle value and limit.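

A second replacement on this nitrogen now points the same way as the first, with this assay showing an at least 5.1-fold higher number from compound 1 to compound 3 (0.71 log units; beyond the scatter), so the loss is not confined to 4-chlorophenyl. The value of compound 3 is a limit of the assay and not a number, and it is the same limit as for compound 2: the limit of > 40000 nM in this assay, at which 2 of the 3 values shown sit. The step between these two compounds cannot be read, and the 4-chlorophenyl and 3,4,5-trifluorophenyl groups therefore cannot be ranked against each other.

From the compounds shown here alone, it remains open how a plain phenyl or a 3-chlorophenyl on this nitrogen would read in this assay, and so whether the ethynyl group itself is needed for a measurable value. Also open, going by these compounds, is whether a longer chain leading to the benzenesulfonamide would shift the value of compound 1.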